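Moving the pyridine nitrogen in an aryloxymethyl series

The compounds below may be only part of what the source reports. "The series", "measured", "known", "first", "only" and "open" are said of these compounds alone.

Compound 1 `O=C1c2cc(COc3cccc(F)c3)nn2CCN1c1ccc(F)cc1`: 70%
Compound 2 `O=C1c2cc(COc3ccc(F)cc3)nn2CCN1c1ccc(F)cc1`: 72%
Compound 3 `O=C1c2cc(COc3ccccn3)nn2CCN1c1ccc(F)cc1`: 68%

In a functional assay on HEK293 cells for positive allosteric modulation of metabotropic glutamate receptor 5 (Homo sapiens), read by calcium flux (a lower number here means a smaller maximal response, a higher number a larger maximal response), compound 3 gives the lowest of the three numbers, though its gap to compound 1 and to compound 2 lies within the scatter, so the three compounds cannot be ordered. Compound 4 `O=C1c2cc(COc3cccnc3)nn2CCN1c1ccc(F)cc1` differs from compound 3 by pyridin-3-yl in place of pyridin-2-yl on an oxygen on a saturated carbon. Within the data shown here, no measured step changes the pyridine itself, but the three aryl swaps at the same oxygen were a number 2 percentage points higher from compound 1 to compound 2 (within the scatter), a number 2 percentage points lower from compound 1 to compound 3 (within the scatter) and a number 4 percentage points lower from compound 2 to compound 3 (within the scatter), each within the scatter. Compound 4 is therefore expected to show no step beyond the scatter, a number 2 percentage points higher from compound 3 to compound 4 (within the scatter). For compound 4 the estimated value in this assay is 70%, expected between 58% and 82%.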

Compound 4, largest response reached (Emax), in percent of the reference or control that the assay uses: 69%
The estimate for compound 4 lay 1 percentage points above the measured number, within the range that was stated.
By their numbers in this assay, from the lowest: compounds 3, 4, 1 and 2 (each within the scatter of the next).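

In this assay, pyridin-3-yl in place of pyridin-2-yl on this oxygen gives a number 1 percentage points higher from compound 3 to compound 4 (within the scatter), so the two pyridines cannot be told apart. The comparisons with the fluorophenyl groups read the same, with a number 3 percentage points lower from compound 2 to compound 4 (within the scatter) and a number 1 percentage points lower from compound 1 to compound 4 (within the scatter), so the four ring groups at this position cannot be separated by largest response. No supporting data bear on this result. The compounds shown leave open whether pyridin-4-yl, a saturated cyclohexyl or a ring carrying a carboxylic acid would shift the largest response beyond the scatter.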